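This account rests on a few compounds, and the source may have more. Where it says the series, first, only, none or still open, it means among the compounds named here.

Compound 1 `COC(=O)c1ccc(OCCCCOc2ccc(C(=O)CC3CCCC3)c(C)c2C)cc1` is one of three compounds that have so far been measured in an assay on HEK293 cells for positive allosteric modulation of metabotropic glutamate receptor 3 (Rattus norvegicus), read by thallium flux, with a stated time of 2.5 min (a higher number here means a larger maximal response, a lower number a smaller maximal response), where compound 1 gives 24.2%. In this assay compound 2 `COC(=O)c1ccc(OCCCCOc2ccc(C(=O)CC3CCCC3)c(O)c2C)cc1` gives 22%, and compound 3 `COC(=O)c1ccc(OCCCCOc2ccc(C(=O)CC(C)C)c(C)c2C)cc1` gives 27.3%. Among these three numbers compound 1 stands second highest, with compound 2 nearest, a number 2.2 percentage points lower from compound 1 to compound 2 (within the scatter), and compound 3 furthest, a number 3.1 percentage points higher from compound 1 to compound 3 (within the scatter). Both of these steps stay within the scatter, so on this assay the three compounds are not told apart.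

Compound 4 `Cc1c(OCCCCOc2ccc(C(=O)O)cc2)ccc(C(=O)CC2CCCC2)c1C` has not yet been measured. It differs from compound 1 in a single place: hydrogen in place of methyl on an oxygen next to a carbonyl group. Among the measured compounds shown here, the two measured steps concern a hydroxy in place of a methyl on an aromatic carbon and an isopropyl in place of a cyclopentyl on a saturated chain carbon bound to a carbonyl carbon; neither touches the oxygen next to a carbonyl group, so no measured step speaks directly to this change. What they do show is that two single changes elsewhere on the shared core left the maximal response within the scatter. For the measured compounds named here, on that basis, and with no direct precedent, the step from compound 1 to compound 4 is expected to be small, a number 0.2 percentage points lower from compound 1 to compound 4 (within the scatter), with no clear direction. In this assay compound 4 is therefore estimated at 24%, in a range from 10% to 38%.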

Compound 4, largest response reached (reported as percent of maximum), in percent of the reference or control that the assay uses: 12.2%
Beside the measured number, compound 4's estimate is 11.8 percentage points above it; measured number inside the range.
By their numbers in this assay, from the lowest: compounds 4, 2, 1 and 3 (each within the scatter of the next, the first and the last beyond it).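

In this assay, replacing methoxycarbonyl with carboxy gives a number 12 percentage points lower from compound 1 to compound 4 (beyond the scatter). Among the compounds shown here, this is the only step from compound 1 that lies beyond the scatter, unlike the hydroxy and isopropyl changes elsewhere on the shared core, a number 2.2 percentage points lower from compound 1 to compound 2 (within the scatter) and a number 3.1 percentage points higher from compound 1 to compound 3 (within the scatter). Among the places changed so far, the oxygen next to a carbonyl group is therefore the one where a single change clearly lowers the maximal response, and losing just one methyl is enough to do it. Nothing available here bears on why the response falls at this position.

Only the methyl ester and the free carboxylic acid are shown at this position, so it remains open whether the response depends on the size of the group on this oxygen or on the presence of the ester itself; an ethyl ester or a primary amide in the same place would help to separate these possibilities. As far as these compounds go, it is also open whether the same change would lower the response by a similar amount on the cores of compound 2 and compound 3.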